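The compounds below may be only part of what the source reports. "The series", "measured", "known", "first", "only" and "open" are said of these compounds alone.

In a functional assay on MHCC97H cells (Homo sapiens) for antiproliferative activity, read by MTT assay, with a stated time of 48 h (a higher number here means a weaker inhibitor, a lower number a stronger inhibitor), compound 1 (`COc1ccc2c(/C=C/C(=O)c3cc(OC)c(OC)c(SC)c3)c[nH]c2c1`) gives 112 nM and compound 2 (`COc1cc(C(=O)/C=C/c2c[nH]c3ccccc23)cc([N+](=O)[O-])c1OC`) gives 830 nM as the higher of the two numbers, a gap beyond the scatter. Compound 3 (`COc1cc(C(=O)/C=C/c2c[nH]c3ccccc23)cc(SC)c1OC`) follows from compound 2 with methylsulfanyl in place of nitro on an aromatic carbon, ortho to a methoxy group. For the measured compounds named here, no measured pair isolates this change, so its size in this assay cannot be read directly. Going by the values given here, the only guide is that compound 1, which also carries methylsulfanyl, stands at 112 nM in the same read-out, though it is no exact match for compound 3. A lower number, beyond the scatter, is therefore expected, with a 5.5-fold lower number from compound 2 to compound 3 (0.74 log units; beyond the scatter) as the estimated step. For compound 3 the estimated value is 150 nM (range 40 nM to 550 nM) pending measurement.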

Compound 3, half-maximal inhibitory concentration: 131 nM
The estimate for compound 3 lay 1.1-fold (0.06 log units) above the measured number; the measured number falls inside the stated range.
By their numbers in this assay, from the lowest: compounds 1 and 3 (each within the scatter of the next); then compound 2.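

In this assay the change to methylsulfanyl in place of nitro on an aromatic carbon, ortho to a methoxy group, gives a 6.3-fold lower number from compound 2 to compound 3 (0.80 log units; beyond the scatter) and so can now be read directly at this position. With methylsulfanyl held in place, hydrogen in place of methoxy on an aromatic carbon gives a 1.2-fold higher number from compound 1 to compound 3 (0.07 log units; within the scatter) so that second change shows no separable effect in this read-out. Nothing available explains the size of either step.

Still open, going by these compounds, is how far this position tolerates other groups, such as an amine, a hydroxyl or the longer ethylsulfanyl chain, since only nitro and methylsulfanyl can be compared here. Also open, on these data alone, is whether the nitro to methylsulfanyl step keeps its size on the core of compound 1.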